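This account rests on a few compounds, and the source may have more. Where it says the series, first, only, none or still open, it means among the compounds named here.

Among the compounds with values here, compound 1 `O=C(Nc1cccc(F)c1)c1cncc(N2CC3CC(C2)N3)c1` gives 0.044 nM in an assay on membranes from Cerebral cortex for displacement of a labelled ligand from Neuronal acetylcholine receptor; alpha4/beta2 (Rattus norvegicus) (on this read-out lower numbers stand for stronger inhibition and higher numbers for weaker inhibition), the lowest number among the three compounds measured so far. Compound 2 `O=C(c1cncc(N2CC3CC(C2)N3)c1)N1CCCc2ccccc21` gives 0.196 nM, and compound 3 `O=C(Nc1ccc(Cl)cc1)c1cncc(N2CC3CC(C2)N3)c1` gives 0.404 nM. Within the data shown here, the only recorded single-point step, a 9.2-fold higher number from compound 1 to compound 3 (0.96 log units; beyond the scatter), swapped one substituted phenyl ring for another on the amide-type nitrogen and already weakened binding beyond the scatter. Compound 4 `O=C(NCc1ccccc1)c1cncc(N2CC3CC(C2)N3)c1` differs from compound 1 by benzyl in place of 3-fluorophenyl on an amide-type nitrogen. Among the measured compounds shown here, no measured pair shows this exact exchange, so the expectation rests on compound 1 and on the step to compound 3, where a change at the amide-type nitrogen only weakened binding. Compound 4 is therefore expected to come in at 0.4 nM, between 0.1 nM and 2 nM, which would mean an expected weakening step of a 9.1-fold higher number from compound 1 to compound 4 (0.96 log units; beyond the scatter).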

Compound 4, inhibition constant: 1.8 nM
Beside the measured number, compound 4's estimate is 4.5-fold (0.65 log units) below it; low and high end bracket the measured number.
By their numbers in this assay, from the lowest: compound 1; then compound 2; then compound 3; then compound 4.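

In this assay, benzyl on the amide-type nitrogen gives a 41-fold higher number from compound 1 to compound 4 (1.61 log units; beyond the scatter), a larger step than the exchange of one substituted phenyl ring for another, and a 4.5-fold higher number from compound 3 to compound 4 (0.65 log units; beyond the scatter) shows that it also weakens binding relative to the 4-chlorophenyl compound. Benzyl and 3-fluorophenyl have equal heavy-atom counts and one aromatic ring each, so these counts alone do not set the number at this position. No measurement here explains the loss. Going by these compounds, whether a longer chain such as 2-phenylethyl, or a fluorine on the benzyl ring, would weaken binding further remains open.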